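The source may report more compounds than this note shows. Statements on the series, on what has been measured and on what is new or still open speak of the compounds shown alone.

Values in a functional assay on MDA-MB-231 cells (Homo sapiens) for inhibition, read by MTT assay, with a stated time of 48 h; a higher number here means a weaker inhibitor, a lower number a stronger inhibitor:
- compound 1 `COc1ccc(N(C)c2nc(C)nc3ccccc23)cc1C(=O)OCC[Se]C#N`: 1480 nM
- compound 2 `COc1ccc(N(C)c2nc(C)nc3ccccc23)cc1[Se]C`: 10 nM
- compound 3 `COc1ccc(N(C)c2nc(C)nc3ccccc23)cc1OCC[Se]C#N`: 13 nM

Compound 1 has the highest number of the three, and both gaps lie beyond the scatter: a 110-fold lower number from compound 1 to compound 3 (2.06 log units; beyond the scatter) and a 150-fold lower number from compound 1 to compound 2 (2.17 log units; beyond the scatter). The change to compound 4 `COc1ccc(N(C)c2nc(C)nc3ccccc23)cc1C(=O)OCCCCCC[Se]C#N` is a group of 7 heavy atoms (5 carbon, 1 nitrogen, 1 selenium; no ring) in place of a group of 3 heavy atoms (1 carbon, 1 nitrogen, 1 selenium; no ring), on a saturated chain carbon, two bonds along the chain from an oxygen next to a carbonyl group. Those two large steps replace the whole group on an aromatic carbon, so neither tests a change of chain length at this place. Going by the values given here, with no measured step on this chain, no step beyond the scatter is expected in this assay, and no direction is favoured. The expected change is a 1.2-fold lower number from compound 1 to compound 4 (0.09 log units; within the scatter). Compound 4 is estimated at 1200 nM, with an expected range of 250 nM to 5000 nM.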

Compound 4, half-maximal inhibitory concentration: 2210 nM
Compound 4: middle estimate off by 1.8-fold (0.27 log units), on the low side; measured number inside the range.
By their numbers in this assay, from the lowest: compounds 2 and 3 (each within the scatter of the next); then compounds 1 and 4 (each within the scatter of the next).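

Chain length at this place is now tested directly: with the 7-heavy-atom group in place of the 3-heavy-atom group on the saturated chain carbon, this assay gives a 1.5-fold higher number from compound 1 to compound 4 (0.17 log units; within the scatter) and does not separate the two compounds. Within this pair, the extra chain carbons therefore bring no readable gain or loss, and the number stays in the range of compound 1. No available evidence bears on why.

Still open, from the compounds shown here alone, is whether a longer chain would behave the same way. Also open, going by these compounds, is whether an amide in place of the ester would shift the number at all.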